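This account rests on a few compounds, and the source may have more. Where it says the series, first, only, none or still open, it means among the compounds named here.

Series notes. Compound 1 `O=C(Nc1cccc(-n2cc(-c3ccncc3)c(-c3cc(O)cc(Cl)c3)n2)c1)Nc1ccc(Cl)c(C(F)(F)F)c1` and compound 2 `COc1cc(Cl)cc(-c2nn(-c3cccc(NC(=O)Nc4ccc(Cl)c(C(F)(F)F)c4)c3)cc2-c2ccncc2)c1` share one core and differ only by methyl in place of hydrogen on an oxygen on an aromatic ring. In a functional assay on SK-MEL-5 cells (Homo sapiens) for inhibition, read by sulforhodamine B assay, with a stated time of 48 h, tested at 0.01 uM (a higher number here means a weaker effect of the compound at the concentration tested, a lower number a stronger effect), compound 1 gives 97%, and in this assay compound 2 gives 96%. For the measured compounds named here, the one measured step, a number 1 percentage points lower from compound 1 to compound 2 (within the scatter), is small, so compound 2 stands alongside compound 1 rather than apart from it; both numbers say that at this concentration neither compound does much in this assay.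

Compound 3 `COc1cc(Cl)cc(-c2nn(-c3cccc(NC(=O)c4cccc(C(F)(F)F)c4)c3)cc2-c2ccncc2)c1` has not yet been measured. It differs from compound 2 on a carbonyl carbon: 3-(trifluoromethyl)phenyl in place of (4-chloro-3-(trifluoromethyl)phenyl)amino on a carbonyl carbon. Going by the values given here, no measured step touches this part of the molecules; the only step in hand concerns the oxygen on an aromatic ring and stayed within the scatter. With both measured values close to the top of the scale, there is little room for a number higher than that of compound 2, and nothing measured argues for a lower one. The step expected in this assay is therefore no change at the digits printed from compound 2 to compound 3 (within the scatter), nothing beyond the scatter. Compound 3 is estimated at 96%, with a range from 84% to 102%.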

Compound 3, a percentage reported as activity, at one concentration (the size of the read-out at that concentration, not a potency): 97%
Estimate against measurement, compound 3: 1 percentage points below; the measured number falls inside the stated range.
By their numbers in this assay, from the lowest: compounds 2, 1 and 3 (each within the scatter of the next).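

For the compounds shown here, at the carbonyl carbon, 3-(trifluoromethyl)phenyl in place of (4-chloro-3-(trifluoromethyl)phenyl)amino is the first exchange read away from the oxygen on the aromatic ring, and in this assay it gives a number 1 percentage points higher from compound 2 to compound 3 (within the scatter), so compound 3 cannot be told apart from compound 2 at this concentration, although the exchange is larger than the one on the oxygen and takes out the amino nitrogen and the chlorine. This is weak information about the position: all three compounds sit close to the top of the scale, where a loss of effect would hardly register, so the result shows that neither group gives a clear effect at this concentration, not that the two groups are equivalent. No measured evidence bears on this result.

On these data alone, whether compounds 2 and 3 would separate at a concentration where the read-out falls well below the top of the scale stays open. Also open, as far as these compounds go, is whether an amine, a carboxylic acid or a longer alkyl chain on the carbonyl carbon would give a clear effect in this assay.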